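The compounds below may be only part of what the source reports. "The series", "measured", "known", "first", "only" and "open" are said of these compounds alone.

Among the measured compounds shown here, in a functional assay on K562 cells (Homo sapiens) for cytotoxicity, read by trypan blue exclusion, with a stated time of 96 h (a lower number here means a stronger inhibitor, a higher number a weaker inhibitor), compound 1 (`COc1cc(OC)c(/C=C/S(=O)(=O)Nc2ccc(OC)c(OP(=O)(O)O)c2)c(OC)c1`) gives 7.5 nM and compound 2 (`COc1cc(OC)c(/C=C/S(=O)(=O)Nc2ccc(OC)c(NC(C)C(=O)O)c2)c(OC)c1`) gives 8 nM, so compound 2 stands within the scatter of the only other measured compound. Compound 3 (`COc1cc(OC)c(/C=C/S(=O)(=O)Nc2ccc(OC)c(NC(C)(C)C(=O)O)c2)c(OC)c1`) differs from compound 2 by methyl in place of hydrogen on a saturated chain carbon bound to a carbonyl carbon, a nitrogen on an aromatic ring and a saturated chain carbon, which turns 1-carboxyethyl into 1-carboxy-1-methylethyl. For the measured compounds named here, the single measured step, a 1.1-fold higher number from compound 1 to compound 2 (0.03 log units; within the scatter), exchanged the whole group on an aromatic carbon and stayed within the scatter, but no measured step tests this methyl. A change no larger than the scatter is therefore expected, with an estimated 1.3-fold higher number from compound 2 to compound 3 (0.10 log units; within the scatter). For compound 3 the estimated value is 10 nM, with an expected range of 4 nM to 30 nM.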

Compound 3, half-maximal inhibitory concentration: 5 nM
Compound 3: middle estimate off by 2.0-fold (0.30 log units), on the high side; the range from low to high includes it.
By their numbers in this assay, from the lowest: compounds 3, 1 and 2 (each within the scatter of the next).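

Placing methyl on the saturated chain carbon bound to a carbonyl carbon, a nitrogen on an aromatic ring and a saturated chain carbon gives a 1.6-fold lower number from compound 2 to compound 3 (0.20 log units; within the scatter) in this assay, so this position accepts the methyl without a step beyond the scatter. The 1-carboxy-1-methylethyl group also stays level with the group on compound 1, with a 1.5-fold lower number from compound 1 to compound 3 (0.18 log units; within the scatter). No measurement shown here bears on either step. Still open, going by these compounds, is whether an ethyl group could take this place, and whether a primary amide could replace the carboxylic acid.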